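Swapping chlorines for fluorines on a chalcone-like pyrazole

The source may report more compounds than this note shows. Statements on the series, on what has been measured and on what is new or still open speak of the compounds shown alone.

Of the compounds shown here, two of one shared core have been measured. Compound 1 `COc1ccc(-c2cc(/C=C/C(=O)c3ccc(N)cc3)[nH]n2)cc1` carries an aminophenyl group on its carbonyl carbon; in a functional assay on OVCAR-3 cells (Homo sapiens) for cytotoxicity, read by sulforhodamine B assay, with a stated time of 48 h, tested at 100 uM (on this read-out higher numbers stand for a weaker effect at the one concentration tested and lower numbers for a stronger effect), compound 1 gives -85%. Compound 2 `COc1cc(-c2cc(/C=C/C(=O)c3ccc(Cl)c(Cl)c3)[nH]n2)cc(OC)c1OC` instead carries a 3,4-dichlorophenyl group on that carbonyl carbon and a trimethoxyphenyl group on the other side of the core; in this assay compound 2 gives -30%. Of the two numbers, compound 2 holds the higher one, and its gap to compound 1 lies beyond the usual scatter, so compound 2 shows the weaker effect at the single concentration tested.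

Compound 3 `COc1cc(-c2cc(/C=C/C(=O)c3ccc(F)c(F)c3)[nH]n2)cc(OC)c1OC` is the next step. Compared with compound 2 it differs in one place only: 3,4-difluorophenyl in place of 3,4-dichlorophenyl on a carbonyl carbon. Within the data shown here, no pair of measured compounds shows the effect of this kind of swap, so the size of the move can only be guessed. The expectation is a small step, if any, from compound 2 to compound 3, within or near the scatter, of a number 10 percentage points higher from compound 2 to compound 3 (within the scatter). Compound 3 is therefore estimated to give -20%, with a likely range from -55% to 10%.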

Compound 3, a percentage reported as activity, at one concentration (the size of the read-out at that concentration, not a potency): -64%
The estimate for compound 3 lay 44 percentage points above the measured number, outside the stated range (below it).
By their numbers in this assay, from the lowest: compound 1; then compound 3; then compound 2.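

Among these compounds, this is the first pair of compounds that differ in one place only, and it shows that the choice of halogen on the phenyl group on this carbonyl carbon matters: in this assay, 3,4-difluorophenyl in place of 3,4-dichlorophenyl gives a number 34 percentage points lower from compound 2 to compound 3 (beyond the scatter). Since lower numbers stand for a stronger effect here, the fluorine-bearing compound 3 acts more strongly at the one concentration tested, even though the two groups match in heavy-atom count, ring, and hydrogen-bond donors and acceptors. No measurement at hand explains why this exchange moves the read-out so far.

As far as these compounds go, it remains open whether the effect depends on having two halogens on this ring, or whether a single fluorine, a trifluoromethyl group or a 3,4-dimethoxyphenyl group at the same place would give a similar result. Among the compounds shown here, it also remains open whether the same exchange would move the read-out in the same direction and by a similar amount with a different group on the other side of the core, such as the one carried by compound 1.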